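Trifluorophenyl Tail Expected to Slow Membrane Passage

The source may report more compounds than this note shows. Statements on the series, on what has been measured and on what is new or still open speak of the compounds shown alone.

Compound 3 `Cc1c(F)cccc1CCCCOc1ccc(/C=C/c2cccc3c(CCCC(=O)O)c(C)n(CC(=O)O)c23)cc1` stands highest of the three compounds measured in a physicochemical assay for permeability, using PAMPA, with a stated time of 4 h, at pH 7.4, tested at 50 uM; a higher number here means that the compound crosses the layer faster, a lower number that the compound crosses the layer more slowly: compound 3 gives 1.5 10^-6 cm/s. Compound 1 `Cc1c(CCCC(=O)O)c2cccc(/C=C/c3ccc(OCCCCc4c(F)c(F)cc(F)c4F)cc3)c2n1CC(=O)O` gives 0.5 10^-6 cm/s in this assay, and compound 2 `Cc1c(CCCC(=O)O)c2cccc(/C=C/c3ccc(OCCCCc4c(F)cc(F)c(F)c4F)cc3)c2n1CC(=O)O` gives 0.3 10^-6 cm/s. Between the two tetrafluorophenyl compounds the step is a 1.7-fold lower number from compound 1 to compound 2 (0.22 log units; within the scatter).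

Compound 4 `Cc1c(CCCC(=O)O)c2cccc(/C=C/c3ccc(OCCCCc4c(F)ccc(F)c4F)cc3)c2n1CC(=O)O` has not yet been measured. It differs from compound 3 in one place: 2,3,6-trifluorophenyl in place of 3-fluoro-2-methylphenyl on a saturated chain carbon, four bonds along the chain from an oxygen on an aromatic ring.

Among the measured compounds shown here, the steps that bear on this change are a 3.0-fold higher number from compound 1 to compound 3 (0.48 log units; beyond the scatter) and a 5.0-fold higher number from compound 2 to compound 3 (0.70 log units; beyond the scatter). Both replaced a tetrafluorophenyl with the 3-fluoro-2-methylphenyl of compound 3 and raised the number. The change to compound 4 runs part of the way back, since a ring carrying three fluorines is closer to the tetrafluorophenyl rings of compound 1 and compound 2 than to the ring of compound 3. A drop is therefore expected, smaller than the rise seen in those steps: the expected step is a 2.1-fold lower number from compound 3 to compound 4 (0.33 log units; beyond the scatter). Compound 4 is estimated to give 0.7 10^-6 cm/s, with a likely range from 0.35 10^-6 cm/s to 1.4 10^-6 cm/s.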

Compound 4, apparent permeability: 2.6 10^-6 cm/s
Beside the measured number, compound 4's estimate is 3.7-fold (0.57 log units) below it; measured number above the stated range.
By their numbers in this assay, from the lowest: compounds 2 and 1 (each within the scatter of the next); then compounds 3 and 4 (each within the scatter of the next).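

In this assay, the change from 3-fluoro-2-methylphenyl to 2,3,6-trifluorophenyl gives a 1.7-fold higher number from compound 3 to compound 4 (0.24 log units; within the scatter), so this position accepts either ring without a change that can be told from the scatter. The tetrafluorophenyl compounds are the ones set apart: replacing one ring fluoro with hydrogen gives a 5.2-fold higher number from compound 1 to compound 4 (0.72 log units; beyond the scatter) and an 8.7-fold higher number from compound 2 to compound 4 (0.94 log units; beyond the scatter), both beyond the scatter. The number therefore does not follow a simple count of fluorines, since the trifluorophenyl compound 4 stands with the monofluorinated compound 3 and clear of both tetrafluorophenyl compounds.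

No supporting measurement explains why losing one fluoro makes this difference. Also open, as far as these compounds go, is how the number would respond to a chloro or methoxy group on this ring, or to a longer chain leading to it.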